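Compound 3 to compound 4: bromo in place of fluoro

The source may hold more compounds than are shown below. What is called first, only, known or untested is meant among the compounds shown, and "the series" means these compounds.

Measured in an ADME assay on L02 cells (Homo sapiens) for cytotoxicity, read by MTT assay, with a stated time of 24 h; on this read-out higher numbers stand for weaker inhibition and lower numbers for stronger inhibition:
- Compound 1 `Cc1ccc(S(=O)(=O)N2C/C(=C\c3ccncc3)C(=O)/C(=C/c3ccccc3F)C2)cc1`: > 20000 nM (a limit of the assay)
- Compound 2 `O=C1/C(=C/c2ccncc2)CN(S(=O)(=O)c2ccc(C(F)(F)F)cc2)C/C1=C\c1ccccc1F`: 18600 nM
- Compound 3 `O=C1/C(=C/c2ccncc2)CN(S(=O)(=O)c2ccc(F)cc2)C/C1=C\c1ccccc1F`: 15600 nM

Compound 3, at 15600 nM, lies within the scatter of compound 2, at 18600 nM. Compound 1 gives only a limit, > 20000 nM.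

Compound 4 `O=C1/C(=C/c2ccncc2)CN(S(=O)(=O)c2ccc(Br)cc2)C/C1=C\c1ccccc1F` has not yet been measured. It carries bromo in place of fluoro on an aromatic carbon, para to a large group: bromo in place of fluoro on an aromatic carbon.

The measured steps that bear on this change are exchanges at that same place. One is a measured step, a 1.2-fold lower number from compound 2 to compound 3 (0.08 log units; within the scatter). The other two are only floors, an at least 1.0-fold lower number from compound 1 to compound 2 (0.03 log units; that floor lies within the scatter) and an at least 1.2-fold lower number from compound 1 to compound 3 (0.10 log units; that floor lies within the scatter). None of the three shows a change beyond the scatter, so no step beyond the scatter is expected in this assay for bromo either. The estimated step is a 1.0-fold lower number from compound 3 to compound 4 (0.02 log units; within the scatter), with no clear direction expected. The value expected for compound 4 is 15000 nM, with an estimated range of 9000 nM to 20000 nM.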

Compound 4, half-maximal inhibitory concentration: 19400 nM
For compound 4 the middle estimate is 1.3-fold (0.11 log units) below the measured one; the range from low to high includes it.
By their numbers in this assay, from the lowest: compounds 3, 2 and 4 (each within the scatter of the next). At a limit, above all of these: compound 1.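

In this assay, bromo joins fluoro and trifluoromethyl at this place with no step beyond the scatter: a 1.2-fold higher number from compound 3 to compound 4 (0.09 log units; within the scatter) and a 1.0-fold higher number from compound 2 to compound 4 (0.02 log units; within the scatter). Compounds 2, 3 and 4 therefore cannot be put in any order, and three different groups on this aromatic carbon, para to a large group, now read alike. Against compound 1 only a floor can be read, an at least 1.0-fold lower number from compound 1 to compound 4 (0.01 log units; that floor lies within the scatter), because compound 1 gives a limit of the assay and not a number: the limit of > 20000 nM in this assay, at which 1 of the 4 values shown sits.

On these data alone, whether an amine or a carboxylic acid at this place would give a step beyond the scatter stays open. So does whether a change elsewhere on the shared core would do so, as the compounds shown differ only at this one place.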